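The compounds below may be only part of what the source reports. "The series", "measured", "known", "first", "only" and "open" are said of these compounds alone.

Measured compounds:
compound 1 `CCOC(=O)C1=C(N/N=C(/C(=O)Br)c2ccc(Br)cc2)Nc2[nH]nc(C)c2C1c1ccc(N(C)C)cc1` — 68500 nM
compound 2 `CCOC(=O)C1=C(N/C=N/c2ncc(-c3ccccc3)s2)Nc2[nH]nc(C)c2C1c1ccc(N(C)C)cc1` — 15400 nM
compound 3 `CCOC(=O)C1=C(N/C=N/c2ccc(C)cc2)Nc2[nH]nc(C)c2C1c1ccc(N(C)C)cc1` — 43200 nM

In a functional assay on HeLa cells (Homo sapiens) for inhibition, read by MTT assay, with a stated time of 48 h (on this read-out lower numbers stand for stronger inhibition and higher numbers for weaker inhibition), compound 1 sits at the upper end of the three numbers. Its separation from compound 3 is a 1.6-fold lower number from compound 1 to compound 3 (0.20 log units; within the scatter), whereas the number of compound 2, 15400 nM, lies clearly under that of compound 1, 68500 nM.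

Compound 4 `CCOC(=O)C1=C(N/N=C(/C(C)=O)C(=O)OCC)Nc2[nH]nc(C)c2C1c1ccc(N(C)C)cc1` has not yet been tested in this assay. Relative to compound 1 the change is a group of 10 heavy atoms (6 carbon, 1 nitrogen, 3 oxygen; no ring) in place of a group of 12 heavy atoms (8 carbon, 1 nitrogen, 1 oxygen, 2 bromine; one six-membered aromatic ring of carbon only), on an amine nitrogen. Among the measured compounds shown here, two measured steps touch on this region of the shared core. The step of a 1.6-fold lower number from compound 1 to compound 3 (0.20 log units; within the scatter) exchanged the same departing group for an aryl amidine and produced no shift beyond the scatter. The step of a 2.8-fold higher number from compound 2 to compound 3 (0.45 log units; beyond the scatter) swapped one ring for another on the double-bonded nitrogen and gave a modest shift. For the measured compounds named here, neither step replaces the ring with a ringless group, so no measured step matches the change to compound 4 directly, and the two steps that do exist point to small effects.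

Compound 4 is therefore expected to give a number close to that of compound 1, with the step of a 1.2-fold higher number from compound 1 to compound 4 (0.07 log units; within the scatter) estimated to stay within or just beyond the scatter. Compound 4 is estimated at 80000 nM, in a range from 30000 nM to 200000 nM.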

Compound 4, half-maximal inhibitory concentration: > 100000 nM
Compound 4 ended at the assay's limit; the forecaster's own chance of this, stated with the estimate: 20%; middle value at least 1.2-fold (0.09 log units) from the limit.
By their numbers in this assay, from the lowest: compound 2; then compounds 3 and 1 (each within the scatter of the next). At a limit, above all of these: compound 4.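

In this assay compound 4 stands at a limit of the assay and not at a number: the limit of > 100000 nM in this assay, at which 1 of the 4 values shown sits.

Among the compounds shown here, this gives the first group without a ring on the amine nitrogen whose other neighbour is the double-bonded ring carbon, and its two steps read differently: an at least 1.4-fold higher number from compound 1 to compound 4 (0.16 log units; that floor lies within the scatter) has a floor that does not separate the two compounds, whereas an at least 2.3-fold higher number from compound 3 to compound 4 (0.36 log units; beyond the scatter) is beyond the scatter even at its floor. Among the compounds shown, therefore, the three groups carrying a six-membered aromatic ring all give readable numbers, the ringless group with its added carbonyl oxygen reaches the limit, and no compound goes against this, though a single ringless example cannot carry it far.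

On these data alone, how far compound 4 lies past the limit stays open, so both steps are known only by their floors. Also open, as far as these compounds go, is whether the loss of the aromatic ring or the ester and ketone carbonyls of the entering group goes with this result, and whether a cyclohexyl ring, a plain alkyl chain or a carboxylic acid in this place would behave like compound 3 or like compound 4.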